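Ethoxy to methoxy on the amide of compound 2

A few compounds are considered here, and "the series" means these few. Any claim that something is new, unique, unknown or untested is made for them only; others in the source may bear on it.

Measured:
- compound 1, `Cc1nnc(-c2sc(-c3cccc(F)c3)nc2O)o1`, in an assay on HEK293 cells for inhibition of transient receptor potential cation channel subfamily M member 8 (Homo sapiens), read by FLIPR, with stated times of 5 min and 3 min; on this read-out lower numbers stand for stronger inhibition and higher numbers for weaker inhibition: 9100 nM
- compound 2, `CCON(C)C(=O)c1sc(-c2cccc(F)c2)nc1O`, in this assay: 1680 nM

Compound 2 holds the lowest number of the two; compound 1 is its nearest neighbour, with a higher number, and the gap lies beyond the scatter. Compound 3, `CON(C)C(=O)c1sc(-c2cccc(F)c2)nc1O`, differs from compound 2 by hydrogen in place of methyl on a saturated chain carbon bound to an oxygen on an unsaturated carbon. Among the compounds with values here, no measured pair covers this change, so nothing here tells its direction; a step of no more than the scatter is expected in this assay, which is what a 1.1-fold higher number from compound 2 to compound 3 (0.03 log units; within the scatter) expresses as an estimate. Compound 3 is expected at 1800 nM, with a range from 700 nM to 4500 nM.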

Compound 3, half-maximal inhibitory concentration: 96 nM
Beside the measured number, compound 3's estimate is 19-fold (1.27 log units) above it, outside the stated range (below it).
By their numbers in this assay, from the lowest: compound 3; then compound 2; then compound 1.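

In this assay, removing one methyl from the ethoxy group is not a minor edit at this position: ethoxy to methoxy gives an 18-fold lower number from compound 2 to compound 3 (1.24 log units; beyond the scatter) and makes the amide chain length a sharp determinant of the read-out. With the methoxy(methyl)carbamoyl group in place of 5-methyl-1,3,4-oxadiazol-2-yl, the series shows a 95-fold lower number from compound 1 to compound 3 (1.98 log units; beyond the scatter) on the shared core. No evidence on hand bears on the size of either step.

Still open, going by these compounds, is how the number moves with a propoxy chain or a plain dimethylamino group on the amide carbonyl. Also open, on these data alone, is whether a carboxylic acid in place of the amide keeps any of this gain.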